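The source may report more compounds than this note shows. Statements on the series, on what has been measured and on what is new or still open speak of the compounds shown alone.

Compound 1 `COc1cc(-c2cc(-c3ccc(Br)cc3)nc(-c3ccccc3)n2)cc(OC)c1OC` and compound 2 `COc1cc(-c2cc(-c3ccccc3)nc(-c3ccccc3)n2)cc(OC)c1OC` share one core and differ only in the substituent on one aryl ring. In a functional assay on MDA-MB-231 cells (Homo sapiens) for inhibition, read by MTT assay, with a stated time of 48 h (on this read-out higher numbers stand for weaker inhibition and lower numbers for stronger inhibition), compound 1 gives only a limit, > 25000 nM. In this assay, going by the values given here, compound 2 gives 5870 nM, the sole number so far. The other value in the pair, that of compound 1, is a limit (the limit of > 25000 nM in this assay, at which 1 of the 2 values shown sits). Among the compounds with values here, the single measured step is an at least 4.2-fold lower number from compound 1 to compound 2 (0.62 log units; beyond the scatter).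

Compound 3 `COc1cc(-c2cc(-c3cccc4ccccc34)nc(-c3ccccc3)n2)cc(OC)c1OC` is not yet measured; it differs from compound 2 by naphthalen-1-yl in place of phenyl on an aromatic carbon, on the same aromatic carbon of the core where compound 1 and compound 2 carry their differing aryl groups. The measured step bears on this change only loosely: there a bromo on the phenyl went with the higher number, here the phenyl itself is enlarged to naphthalen-1-yl. Growth at this site, seen in the step of an at least 4.2-fold lower number from compound 1 to compound 2 (0.62 log units; beyond the scatter), went with the weaker compound, so a modest step toward a higher number is expected for compound 3, a 1.7-fold higher number from compound 2 to compound 3 (0.23 log units; within the scatter), with a fair chance that only a limit is returned. Compound 3 is accordingly estimated at 10000 nM, within 3000 nM to 25000 nM.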

Compound 3, half-maximal inhibitory concentration: 3240 nM
The estimate for compound 3 lay 3.1-fold (0.49 log units) above the measured number, within the range that was stated.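

Replacing phenyl with naphthalen-1-yl on this aromatic carbon, next to the ring nitrogen, does not repeat the loss seen with the bromo of compound 1: in this assay the change gives a 1.8-fold lower number from compound 2 to compound 3 (0.26 log units; within the scatter), so compound 2 and compound 3 cannot be told apart. Added size at this site therefore does not by itself go with weaker inhibition, since the second aromatic ring of naphthalen-1-yl is accepted here while the 4-bromophenyl group is not, with an at least 7.7-fold lower number from compound 1 to compound 3 (0.88 log units; beyond the scatter). That step is a bound rather than a measured size, because one of its ends is a limit: the limit of > 25000 nM in this assay, at which 1 of the 3 values shown sits.

Going by these compounds, it remains open whether this carbon accepts anything other than an aryl group, such as an amine, a carboxylic acid or a longer alkyl chain, and whether a smaller fluoro or a methoxy on the phenyl would behave like the bromo. The other aryl groups on the shared core stay constant throughout the compounds shown, so what they contribute to inhibition cannot be read from this set.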